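A few compounds are considered here, and "the series" means these few. Any claim that something is new, unique, unknown or untested is made for them only; others in the source may bear on it.

In a functional assay on HL-60 cells (Homo sapiens) for antiproliferative activity, read by MTT assay, with a stated time of 72 h (a higher number here means a weaker inhibitor, a lower number a stronger inhibitor), compound 1 `NC1=NC2(CCOCC2)N(OCCCOc2ccc(Cl)cc2)C(N)=N1` gives 330 nM and compound 2 `NC1=NC2(CCOCC2)N(OCCCOc2ccc(F)cc2)C(N)=N1` gives 2380 nM. Compound 3 `Cc1cc(C)cc(OCCCON2C(N)=NC(N)=NC23CCOCC3)c1` gives 720 nM, the middle of the three numbers and closer to compound 1 than to compound 2.

Compound 4 `NC1=NC2(CCOCC2)N(OCCCOc2ccc(Cl)cc2Cl)C(N)=N1` has not yet been measured. Its difference from compound 3 is 2,4-dichlorophenyl in place of 3,5-dimethylphenyl on an oxygen on a saturated carbon, with 2,4-dichlorophenyl in place of 3,5-dimethylphenyl on an oxygen on a saturated carbon.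

The most relevant measured change is a 2.2-fold higher number from compound 1 to compound 3 (0.34 log units; beyond the scatter), which replaces 4-chlorophenyl with 3,5-dimethylphenyl. Also relevant are a 7.2-fold higher number from compound 1 to compound 2 (0.86 log units; beyond the scatter), where fluoro replaces chloro, and a 3.3-fold lower number from compound 2 to compound 3 (0.52 log units; beyond the scatter). All three are modest steps, and the chloro compound 1 has the lowest number. Going by the values given here, no measured compound carries 2,4-dichlorophenyl, so the contribution of the second chlorine remains unknown. A modest move toward a lower number in this assay is therefore expected, similar in size to the step between compound 1 and compound 3, but in the opposite direction.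

The expected step is a 2.4-fold lower number from compound 3 to compound 4 (0.38 log units; beyond the scatter).

Compound 4 is estimated at 300 nM, with an expected range of 100 nM to 900 nM.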

Compound 4, half-maximal inhibitory concentration: 330 nM
Compound 4: the middle estimate sits 1.1-fold (0.04 log units) below what was measured; the measured number falls inside the stated range.
By their numbers in this assay, from the lowest: compounds 1 and 4 (each within the scatter of the next); then compound 3; then compound 2.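

In this assay, chloro in place of hydrogen on an aromatic carbon gives no change at the digits printed from compound 1 to compound 4 (within the scatter), so the 2,4-dichlorophenyl group reads the same as the 4-chlorophenyl group at this place on the oxygen. The other new steps, a 2.2-fold lower number from compound 3 to compound 4 (0.34 log units; beyond the scatter) and a 7.2-fold lower number from compound 2 to compound 4 (0.86 log units; beyond the scatter), extend the picture: both chlorine-bearing compounds, compound 1 and compound 4, carry lower numbers than the dimethyl compound 3 and the fluoro compound 2. No measurement at hand bears on why the added chlorine leaves the number unmoved.

Still open, on these data alone, is how bromo, methoxy or trifluoromethyl in place of chloro would read on this aromatic ring. Also open, as far as these compounds go, are the effects of a longer chain in place of the present one and of any change to the shared core, which all four compounds keep.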